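The source may hold more compounds than are shown below. What is called first, only, known or untested is meant among the compounds shown, and "the series" means these compounds.

Measured compounds:
compound 1 `O=C(NCC1CCOCC1)c1cnc(Nc2cc(Cl)cc(Cl)c2)cc1C1CC1`: "not determined" (no result reported)
compound 2 `O=C(NCC1CCOCC1)c1cnc(Nc2cccc(F)c2)cc1C1CC1`: "not determined" (no result reported)
compound 3 `CC(C)(C)c1cc(Nc2ccc(Cl)cc2Cl)ncc1C(=O)NCC1CCOCC1`: 267000000 ng.h/mL

In an ADME assay on the whole organism for pharmacokinetics, with Rattus norvegicus as the target, with a stated time of 6 h, at a dose of 30 mg/kg by the oral route (a higher number here means more compound in the circulation at the dose given, a lower number less compound in the circulation), compound 3 gives 267000000 ng.h/mL. Compound 2 stands without a number of its own in this assay, and compound 1 is a further entry without one. Compound 4 `O=C(NCC1CCOCC1)c1cnc(Nc2cccc(Br)c2)cc1C1CC1` has not yet been measured there. Compound 4 differs from compound 2 by bromo in place of fluoro on an aromatic carbon. Among the compounds with values here, since no step between measured compounds is available, the step from compound 2 to compound 4 in this assay is expected to stay within the usual scatter, with no set direction. Compound 3 differs from compound 4 in more than one place, so its number is only a rough guide. Compound 4 is estimated at 5000000 ng.h/mL in this assay, with a range from 50000 ng.h/mL to 300000000 ng.h/mL.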

Compound 4, area under the concentration-time curve: 83400000 ng.h/mL
Estimate against measurement, compound 4: 17-fold (1.22 log units) below; measured number inside the range.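

In this assay, within the data shown here, compound 2 gives "not determined" (no result reported) and so no step to compound 4 can be read. The compounds shown leave open how bromo compares with fluoro on the shared core. Nothing shown bears on the result.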